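Lipophilicity notes: the step from compound 2 to compound 4

This account rests on a few compounds, and the source may have more. Where it says the series, first, only, none or still open, it means among the compounds named here.

Measured so far:
compound 1 `O=C(N/N=C\c1ccc(Oc2ccc3ccccc3c2)cc1)c1ccncc1` — 4.52
compound 2 `Cc1ccc(Oc2ccc(/C=N\NC(=O)c3ccncc3)cc2)cc1` — 3.65
compound 3 `O=C1Nc2ccccc2/C1=N\NC(=O)c1ccncc1` — 1.12

All three numbers come from a physicochemical assay for lipophilicity, in phosphate buffer, measured as octanol-water partition, with a stated time of 24 h; a lower number here means a more polar compound, a higher number a more lipophilic compound. Compound 2 stands second highest of the three. Compound 1 sits higher than compound 2, and the gap is beyond the usual scatter of this assay. Compound 3 sits far lower than compound 2, again beyond the scatter, so the three values are well separated from one another.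

Compound 4 `O=C(N/N=C\c1ccc(Oc2ccc(Cl)cc2)cc1)c1ccncc1` has not yet been measured in this assay. Its difference from compound 2 is chloro in place of methyl on an aromatic carbon. Going by the values given here, no pair of measured compounds shows this same exchange, so nothing measured here tells directly how large the step will be.

The expectation for compound 4 is a small upward step in this assay, a number 0.15 log units higher from compound 2 to compound 4 (within the scatter), which is not expected to exceed the scatter of repeated measurements. On that basis compound 4 is estimated at 3.8 in this assay, with a range from 3.4 to 4.2.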

Compound 4, partition coefficient: 3.95
Compound 4: the middle estimate sits 0.15 log units below what was measured; low and high end bracket the measured number.
By their numbers in this assay, from the lowest: compound 3; then compounds 2 and 4 (each within the scatter of the next); then compound 1.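

In this assay, going by these compounds alone, chloro in place of methyl on an aromatic carbon, para to a large group, gives a number 0.30 log units higher from compound 2 to compound 4 (within the scatter) and is the only step so far that can be read across a single place. Compounds 1, 2 and 3 differ from one another in more than one place, so they could not show what this one change does on its own; the pair now shows that 4-methylphenoxy and 4-chlorophenoxy cannot be told apart in this read-out, even though the step reaches the edge of the usual scatter of repeated measurements. No measurement at hand speaks to what lies behind the size of this step.

Within the data shown here, a single pair covers only one exchange at one place, so it remains open how other groups on this aromatic carbon would read in this assay, for instance an amine, a carboxylic acid or a longer alkyl chain. As far as these compounds go, it is equally open whether chloro in place of methyl would give a step of similar size elsewhere on the shared core.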